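Methoxy to dimethylamino on the terminal phenyl, hydroxy core

A few compounds are considered here, and "the series" means these few. Any claim that something is new, unique, unknown or untested is made for them only; others in the source may bear on it.

Compound 1 `COc1ccc(-c2ccc(-c3ccc(-c4nc5ccccc5[nH]4)cc3)cc2)cc1` and compound 2 `CN(C)c1ccc(-c2ccc(-c3ccc(-c4nc5ccccc5[nH]4)cc3)cc2)cc1` share one core; compound 3 `COc1ccc(-c2ccc(-c3ccc(-c4nc5c(O)cccc5[nH]4)cc3)cc2)cc1` and compound 4 `CN(C)c1ccc(-c2ccc(-c3ccc(-c4nc5c(O)cccc5[nH]4)cc3)cc2)cc1` share another. The two cores differ by hydroxy in place of hydrogen on an aromatic carbon; that change gives a 16-fold lower number from compound 1 to compound 3 (1.19 log units; beyond the scatter). In a functional assay on DWD cells (Homo sapiens) for inhibition, read by sulforhodamine B assay (on this read-out higher numbers stand for weaker inhibition of growth and lower numbers for stronger inhibition of growth), compound 1 gives 100000 nM, compound 2 gives 100000 nM, and compound 3 gives 6400 nM.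

The change dimethylamino in place of methoxy on an aromatic carbon has been measured once, giving no change at the digits printed from compound 1 to compound 2 (within the scatter). The same change, (dimethylamino in place of methoxy on an aromatic carbon), has not yet been measured on the hydroxy core. The place lines of the two changes read the same word for word, so this is the same change.

For compound 4 a step of no change at the digits printed from compound 3 to compound 4 (within the scatter) is expected in this assay, because the earlier step of no change at the digits printed from compound 1 to compound 2 (within the scatter) stayed within the scatter; the estimate for compound 4 is therefore 6400 nM, with a range from 2500 nM to 16000 nM.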

Compound 4, concentration for 50% growth inhibition: 9210 nM
For compound 4 the middle estimate is 1.4-fold (0.16 log units) below the measured one; measured number inside the range.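

In this assay, dimethylamino in place of methoxy carries over to the hydroxy core as a step within the scatter, a 1.4-fold higher number from compound 3 to compound 4 (0.16 log units; within the scatter), and it agrees with the step on the other core: the same change on two cores in this assay, no change at the digits printed (within the scatter) from compound 1 to compound 2 and a 1.4-fold higher number (0.16 log units; within the scatter) from compound 3 to compound 4, 1.4-fold (0.16 log units) apart, within the scatter of two such steps. Hydroxy in place of hydrogen likewise stays large with dimethylamino on the terminal phenyl, an 11-fold lower number from compound 2 to compound 4 (1.04 log units; beyond the scatter), and it agrees with the step seen with methoxy: the same change on two cores in this assay, a 16-fold lower number (1.19 log units; beyond the scatter) from compound 1 to compound 3 and an 11-fold lower number (1.04 log units; beyond the scatter) from compound 2 to compound 4, 1.4-fold (0.16 log units) apart, within the scatter of two such steps. On these four compounds the two changes carry across without visible interplay, but this does not show the same for other cores or other assays, and it gives no reason for either step.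

Open, as far as these compounds go, is whether a carboxylic acid or a longer alkoxy chain in place of methoxy would also leave the number within the scatter. Also open, from the compounds shown here alone, is whether an amine in place of the core hydroxy would give a step of like size.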